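A few compounds are considered here, and "the series" means these few. Any claim that something is new, unique, unknown or untested is made for them only; others in the source may bear on it.

Compound 1 `Cc1nc(C)n(CC(=O)N2CCN(c3sc(C(F)(F)F)nc3-c3cnc(OC(C)C)nc3)C[C@H]2C)n1` in an assay on blood for inhibition of C-X-C chemokine receptor type 3 (Homo sapiens), with a stated time of 30 min (on this read-out higher numbers stand for weaker inhibition and lower numbers for stronger inhibition), gives 216 nM.
Compound 2 `Cc1nc(C)n(CC(=O)N2CCN(c3sc(C(F)(F)F)nc3-c3cnc(OC4CCC4)nc3)C[C@H]2C)n1` gives 306 nM.
Compound 3 `Cc1nc(C)n(CC(=O)N2CCN(c3sc(C(F)(F)F)nc3-c3cnc(C(C)(C)C)nc3)C[C@H]2C)n1` gives 1160 nM.

Compound 3 carries the highest number of the three and so the weakest inhibition shown: the step of a 5.4-fold higher number from compound 1 to compound 3 (0.73 log units; beyond the scatter) and the step of a 3.8-fold higher number from compound 2 to compound 3 (0.58 log units; beyond the scatter) both lie beyond the scatter, while a 1.4-fold higher number from compound 1 to compound 2 (0.15 log units; within the scatter) does not. Compound 4 `Cc1nc(C)n(CC(=O)N2CCN(c3sc(C(F)(F)F)nc3-c3cnc(N4CCCC4)nc3)C[C@H]2C)n1` differs from compound 3 in one place: pyrrolidin-1-yl in place of tert-butyl on an aromatic carbon. The two measured steps that bear on this change are those into compound 3, in which tert-butyl replaced an oxygen-linked group and the number rose modestly each time. For the measured compounds named here, replacing tert-butyl in turn is therefore expected to move the number back down by a modest step, a 3.6-fold lower number from compound 3 to compound 4 (0.56 log units; beyond the scatter), although no measured step covers this exact group. Compound 4 is estimated at 320 nM, with a range from 120 nM to 850 nM.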

Compound 4, half-maximal inhibitory concentration: 352 nM
For compound 4 the middle estimate is 1.1-fold (0.04 log units) below the measured one; measured number inside the range.
By their numbers in this assay, from the lowest: compounds 1, 2 and 4 (each within the scatter of the next); then compound 3.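

At this place, between two ring nitrogen atoms, pyrrolidin-1-yl brings the number in this assay back down from the tert-butyl level (a 3.3-fold lower number from compound 3 to compound 4 (0.52 log units; beyond the scatter)). Set against the oxygen-linked groups, it stays within the scatter (a 1.2-fold higher number from compound 2 to compound 4 (0.06 log units; within the scatter); a 1.6-fold higher number from compound 1 to compound 4 (0.21 log units; within the scatter)), so among these four compounds a ring joined through nitrogen cannot be told apart from an isopropoxy or cyclobutyloxy group, and only tert-butyl, joined through carbon, stands apart. Nothing measured here gives a reason for this.

Still open, on these data alone, is whether other amines, such as dimethylamino, piperidin-1-yl or morpholin-4-yl, would stay level with pyrrolidin-1-yl or shift the number.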